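Swapping pyridin-4-yl for 1H-indazol-5-yl on compound 3

The source may hold more compounds than are shown below. What is called first, only, known or untested is meant among the compounds shown, and "the series" means these compounds.

Of the compounds shown here, three have been read in a functional assay on A-431 cells (Homo sapiens), read by propidium iodide staining, with a stated time of 24 h (on this read-out lower numbers stand for an effect already at smaller amounts and higher numbers for an effect only at larger amounts of compound), so far. Compound 1 (`FC(F)(F)c1cccc(-c2nnc(-c3cccnc3NCc3cn[nH]c3)[nH]2)c1`) gives > 10000 nM as a limit of the assay. Compound 3 (`c1ccc(-c2nnc(Nc3ccc4c(c3)OCCO4)[nH]2)c(NCc2ccncc2)c1`) gives > 10000 nM as a limit, so it sits at the limit of > 10000 nM in this assay, at which 2 of the 3 values shown sit, and has no number of its own. Compound 2 (`c1cnc(NCc2cnc[nH]2)c(-c2nnc(Nc3ccc4c(c3)OCCO4)o2)c1`) alone gives a number, at 10 nM in this series.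

Compound 4 (`c1ccc(-c2nnc(Nc3ccc4c(c3)OCCO4)[nH]2)c(NCc2ccc3[nH]ncc3c2)c1`) follows from compound 3 by 1H-indazol-5-yl in place of pyridin-4-yl on a saturated chain carbon bound to a nitrogen on an aromatic ring on the same core. Among the compounds with values here, no measured pair isolates this change. Within the data shown here, compound 2 at 10 nM shows only that a number is attainable. A further limit remains quite possible for compound 4. The expected step is an at least 3.3-fold lower number from compound 3 to compound 4 (0.52 log units; beyond the scatter) in this assay towards lower numbers. The estimated value for compound 4 is 3000 nM (range 150 nM to 20000 nM).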

Compound 4, half-maximal effective concentration: > 10000 nM
Compound 4: a limit, no number; the forecaster's own chance of this, stated with the estimate: 50%; at least 3.3-fold (0.52 log units) between middle value and limit.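

Compound 3 and compound 4 both stand at a limit of the assay with no number of their own, so no step between them can be read: the limit of > 10000 nM in this assay, at which 3 of the 4 values shown sit.

The compounds shown leave open whether pyridin-4-yl and 1H-indazol-5-yl differ at all in this assay.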